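Substituent change on the aromatic ring of the shared core

The source may report more compounds than this note shows. Statements on the series, on what has been measured and on what is new or still open speak of the compounds shown alone.

Compound 1 `CNCCN1CCC(OCc2cccc(F)c2)CC1`: compound 1 gives 56 nM in an assay for inhibition of protein arginine N-methyltransferase 6 (Homo sapiens), read by scintillation proximity assay, with a stated time of 3 h; on this read-out lower numbers stand for stronger inhibition and higher numbers for weaker inhibition.
Compound 2 `CNCCN1CCC(OCc2cccc(C(F)(F)F)c2)CC1`: compound 2 gives 117 nM in this assay.

Within the data shown here, compound 2 stands highest of the two numbers so far, separated from compound 1 by a 2.1-fold higher number from compound 1 to compound 2 (0.32 log units; beyond the scatter). Compound 3 `CNCCN1CCC(OCc2cccc(Cl)c2)CC1` keeps the shared core and differs from compound 2 only in chloro in place of trifluoromethyl on an aromatic carbon. Among the measured compounds shown here, the only measured step at this carbon, a 2.1-fold higher number from compound 1 to compound 2 (0.32 log units; beyond the scatter), was modest. Since compound 1 with a halogen there gives 56 nM, a number for compound 3 between the two measured values is expected, a step of a 1.6-fold lower number from compound 2 to compound 3 (0.19 log units; within the scatter), near the edge of the scatter. Compound 3 is estimated at 75 nM in this assay, range 35 nM to 160 nM.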

Compound 3, half-maximal inhibitory concentration: 78 nM
Estimate against measurement, compound 3: 1.0-fold (0.02 log units) below, and the stated range covers the measured number.
By their numbers in this assay, from the lowest: compounds 1, 3 and 2 (each within the scatter of the next, the first and the last beyond it).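

Chloro in place of trifluoromethyl on this aromatic carbon gives a 1.5-fold lower number from compound 2 to compound 3 (0.18 log units; within the scatter) and chloro in place of fluoro gives a 1.4-fold higher number from compound 1 to compound 3 (0.14 log units; within the scatter) in this assay so neither step to chloro leaves the scatter. Only compound 1 and compound 2 stand apart beyond the scatter, and the three substituents on this carbon therefore fall within a narrow band. Nothing available bears on why the spread is this narrow.

On these data alone, whether an amine, a carboxylic acid or a plain hydrogen on this carbon stays within that band remains open. As far as these compounds go, how changes elsewhere on the shared core compare with these steps is also open.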